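Cytotoxicity notes on a shared-core series and one new analogue

This account rests on a few compounds, and the source may have more. Where it says the series, first, only, none or still open, it means among the compounds named here.

Measured so far in an ADME assay on HepG2 2.2.15 cells (Homo sapiens) for cytotoxicity; on this read-out higher numbers stand for lower toxicity in this test and lower numbers for higher toxicity in this test:
- Compound 1 `COCCNc1ncc(C(Oc2ccc3cc(Br)ccc3c2)c2ccc(Cl)cc2)s1` gives "not toxic" (no number reported) in this assay.
- Compound 2 `CCN(CC)C(=O)Nc1ncc(C(Oc2ccc3cc(Br)ccc3c2)c2ccc(Cl)cc2)s1` gives "not toxic" (no number reported) in this assay.
- Compound 3 `O=C(Nc1ncc(C(Oc2ccc3cc(Br)ccc3c2)c2ccc(Cl)cc2)s1)c1ccc(Br)cc1` gives > 50000 nM in this assay.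

The value of compound 3 is a limit of this assay and not a number; of the three entries it is the only one for which a figure of any kind is given, and it sits at the limit of > 50000 nM in this assay, at which 1 of the 3 values shown sits. The other two entries for compound 1 and compound 2 carry no single number, so compound 3 cannot be placed above or below them; all three entries point the same way, to low toxicity in this test. Going by the values given here, no step between two measured compounds exists here.

Compound 4 `O=S(=O)(Nc1ncc(C(Oc2ccc3cc(Br)ccc3c2)c2ccc(Cl)cc2)s1)c1ccccc1` is the next analogue. It differs from compound 3 as follows: phenylsulfonyl in place of (4-bromophenyl)carbonyl on a nitrogen on an aromatic ring. The change is phenylsulfonyl in place of (4-bromophenyl)carbonyl on a nitrogen on an aromatic ring.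

With nothing in the series falling below the limit, the expected step of a number no higher from compound 3 to compound 4 (the limit leaves the size open) is none beyond the scatter. Compound 4 is expected to give 50000 nM, estimated within 25000 nM to 100000 nM, most likely again reported only as a limit of this assay.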

Compound 4, half-maximal cytotoxic concentration: > 50000 nM
Compound 4: only a limit was reported; the forecaster's own chance of this, stated with the estimate: 80%; the middle value sits exactly at the limit.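

In this assay, compound 3 and compound 4 are each reported only as a limit of the assay, so no step between them can be read: the limit of > 50000 nM in this assay, at which 2 of the 4 values shown sit.

The compounds shown leave open how far phenylsulfonyl and (4-bromophenyl)carbonyl differ on the nitrogen, and at what concentration, if any, cytotoxicity appears across the series.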